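The source may report more compounds than this note shows. Statements on the series, on what has been measured and on what is new or still open speak of the compounds shown alone.

Among the compounds with values here, compound 1, with the structure `CNc1cc(Oc2ccc(NC(=O)Nc3ccccc3)cc2)ncn1`, is one of two compounds measured in an assay on isolated protein for inhibition of serine/threonine-protein kinase TNNI3K (Homo sapiens); a higher number here means a weaker inhibitor, a lower number a stronger inhibitor. Of those two numbers it holds the higher: in this assay compound 1 gives 6300 nM, while compound 2, with the structure `CC(C)CNc1cc(Oc2ccc(NC(=O)Nc3cccc(C(F)(F)F)c3)cc2)ncn1`, gives 50 nM, a gap that lies well beyond the usual scatter of repeated measurements. Compound 2 differs from compound 1 in two places at once, so its number cannot be laid at the door of a single change.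

Within the data shown here, the unmeasured compound 3, with the structure `CNc1cc(Oc2ccc(NC(=O)Nc3cccc(C(C)F)c3)cc2)ncn1`, makes only one change to compound 1: 1-fluoroethyl in place of hydrogen on an aromatic carbon. The rest of the molecule, including the methylamino group on the shared core, stays as in compound 1.

Among the measured compounds shown here, no single-change step is available to calibrate this move, so the expectation rests on what the two values show. Because compound 2, which also carries a substituent on that outer ring, gives 50 nM, the step from compound 1 to compound 3 is expected to run toward a lower number, by about a 7.9-fold lower number from compound 1 to compound 3 (0.90 log units; beyond the scatter). Compound 3 is therefore expected to give 800 nM, within a range from 200 nM to 3000 nM.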

Compound 3, half-maximal inhibitory concentration: 79 nM
The estimate for compound 3 lay 10-fold (1.01 log units) above the measured number; the whole stated range lies above it.
By their numbers in this assay, from the lowest: compounds 2 and 3 (each within the scatter of the next); then compound 1.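

In this assay, the step of an 80-fold lower number from compound 1 to compound 3 (1.90 log units; beyond the scatter) isolates a single change, 1-fluoroethyl in place of hydrogen on an aromatic carbon, meta to a large group. Compound 2 could not show this, since it differs from compound 1 in two places at once, whereas compound 3 keeps the methylamino group of compound 1, so this one substitution on the outer ring is enough on its own for a large step toward a stronger inhibitor. Nothing given here accounts for the size of this step.

The compounds shown leave open which part of the 1-fluoroethyl group matters, a question that an ethyl group or a single methyl group at the same place would help to answer, and whether quite different groups there, such as a methoxy group, an amine or a carboxylic acid, would give a similar number. They also leave open what the larger chain on the amine of compound 2 does by itself, apart from the trifluoromethyl group on its outer ring.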